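A Piperidine Extension on the Amide Side Chain

The source may hold more compounds than are shown below. What is called first, only, known or untested is meant among the compounds shown, and "the series" means these compounds.

Within the data shown here, compound 2 `CCC(=O)Nc1ccc(-c2nc3cc(C(F)(F)F)ccc3[nH]2)cc1` is one of three compounds measured in an ADME assay on Vero cells (Chlorocebus sabaeus) for cytotoxicity; on this read-out lower numbers stand for higher toxicity in this test and higher numbers for lower toxicity in this test. In this assay compound 2 gives only a limit, > 100000 nM. Compound 1 `CCC(=O)Nc1ccc(-c2nc3cc(C(F)(F)F)ccc3n2C2CCCCC2)cc1` likewise gives only a limit, > 100000 nM. Compound 3 `COc1ccc(-c2nc3cc(C(F)(F)F)ccc3[nH]2)cc1` gives 15000 nM. The step that the two limits leave unreadable from compound 1 to compound 2 cannot be read, and the step of an at least 6.6-fold lower number from compound 2 to compound 3 (0.82 log units; beyond the scatter) concerns another position. Compound 4 `O=C(CN1CCCCC1)Nc1ccc(-c2nc3cc(C(F)(F)F)ccc3[nH]2)cc1` differs from compound 2 by piperidin-1-yl in place of methyl on a saturated chain carbon bound to a carbonyl carbon. Among the measured compounds shown here, no measured step touches this chain. Because compound 2 rests at the limit of > 100000 nM in this assay, at which 2 of the 3 values shown sit, compound 4 is expected to remain near that boundary, a step of a number no higher from compound 2 to compound 4 (the limit leaves the size open). Compound 4 is therefore estimated at 100000 nM, within a range from 30000 nM to 300000 nM.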

Compound 4, half-maximal cytotoxic concentration: 31000 nM
Compound 4: the middle estimate sits 3.2-fold (0.51 log units) above what was measured; the range from low to high includes it.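

In this assay, piperidin-1-yl in place of methyl on a saturated chain carbon bound to a carbonyl carbon gives an at least 3.2-fold lower number from compound 2 to compound 4 (0.50 log units; beyond the scatter). Among these compounds, no earlier step touched this chain, so this is the first sign that the read-out responds to a change at this position. The value of compound 2 is only a limit of the assay: the limit of > 100000 nM in this assay, at which 2 of the 4 values shown sit.

On these data alone, whether the change follows from the ring or from its nitrogen stays open; a morpholine, a dimethylamino group or a longer chain at this place could separate the two. Also open, as far as these compounds go, is how piperidin-1-yl would behave with the cyclohexyl of compound 1 on the aromatic nitrogen.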